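Removing the second methoxy from a doubly methoxylated sulfone

The compounds below may be only part of what the source reports. "The series", "measured", "known", "first", "only" and "open" are said of these compounds alone.

Measured compounds:
compound 1, `COc1ccc(-c2[nH]c3ccc(OC)cc3c2/C=C(\C#N)S(=O)(=O)c2ccccc2)cc1`, 359 nM
compound 2, `CC(=O)/C(=C\c1c(-c2ccccc2)[nH]c2ccccc12)S(=O)(=O)c1ccccc1`, 1600 nM
compound 3, `COc1ccc(-c2[nH]c3ccccc3c2/C=C(\C#N)S(=O)(=O)c2ccccc2)cc1`, 244 nM

These three share a core carrying a vinyl sulfone; the read-out is a functional assay on OVCAR-3 cells (Homo sapiens) for inhibition, read by sulforhodamine B assay, with a stated time of 48 h; a higher number here means a weaker inhibitor of growth, a lower number a stronger inhibitor of growth. Compound 1 has the second highest number of the three. Its nearest neighbour is compound 3, reached by a 1.5-fold lower number from compound 1 to compound 3 (0.17 log units; within the scatter), a change that stays within the scatter. Compound 2, which carries an acetyl in place of the nitrile and no methoxy at all, lies farthest from compound 1, beyond the scatter.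

The unmeasured compound 4, `COc1ccc2[nH]c(-c3ccccc3)c(/C=C(\C#N)S(=O)(=O)c3ccccc3)c2c1`, differs from compound 1 by hydrogen in place of methoxy on an aromatic carbon, sitting para to a large group on a six-membered aromatic ring of carbon only. Among the measured compounds shown here, the one measured step of the same kind, from compound 1 to compound 3, removed a methoxy elsewhere and gave a number within the scatter. By that single precedent, the step from compound 1 to compound 4 in this assay is expected to be small, with no clear direction beyond the scatter, as a 1.1-fold lower number from compound 1 to compound 4 (0.05 log units; within the scatter). Compound 4 is therefore estimated at 320 nM, within 150 nM to 700 nM.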

Compound 4, concentration for 50% growth inhibition: 5000 nM
The estimate for compound 4 lay 16-fold (1.19 log units) below the measured number; measured number above the stated range.
By their numbers in this assay, from the lowest: compounds 3 and 1 (each within the scatter of the next); then compound 2; then compound 4.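

The same exchange of methoxy for hydrogen does not count equally at every place on compound 1 in this assay. Turning 4-methoxyphenyl into phenyl gives a 14-fold higher number from compound 1 to compound 4 (1.14 log units; beyond the scatter) and so a much weaker inhibitor of growth, whereas removing the other methoxy gives only a 1.5-fold lower number from compound 1 to compound 3 (0.17 log units; within the scatter), so among these compounds the number depends on the methoxy of the 4-methoxyphenyl. No measurement offered here explains this difference between the two places.

Still open, on these data alone, is whether a hydroxyl, an amine or a longer chain such as ethoxy at that same place would keep the number close to that of compound 1. Also open, as far as these compounds go, is whether this methoxy matters as much when an acetyl replaces the nitrile.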